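Swapping One Stereocentre at the Assay Limit

This account rests on a few compounds, and the source may have more. Where it says the series, first, only, none or still open, it means among the compounds named here.

Measured in an ADME assay on microsomes from liver (Homo sapiens) for metabolic stability, read by LC-MS, using NADPH, with a stated time of 30 min, tested at 0.1 uM, in the presence of a further agent that is not named here; a lower number here means that less of the compound is left, a higher number that more of the compound is left:
- compound 1 `Nc1ncc(-c2ccc(C(=O)N3CC(O)C3)cc2)nc1-c1ccc(C(F)(F)F)cc1`: > 90%
- compound 2 `NC(=O)c1ccc(-c2cnc(N)c(-c3ccc(C(F)(F)F)cc3)n2)cc1`: > 90%
- compound 3 `Nc1ncc(-c2ccc(C(=O)N3CC[C@@H](O)C3)cc2)nc1-c1ccc(C(F)(F)F)cc1`: > 90%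

All three readings are limits of the assay and not numbers, so the series sits together: the limit of > 90% in this assay, at which 3 of the 3 values shown sit.

Compound 3 reads > 90%, which is only a limit. The next compound, compound 4 `Nc1ncc(-c2ccc(C(=O)N3CC[C@H](O)C3)cc2)nc1-c1ccc(C(F)(F)F)cc1`, changes one thing: the two compounds have the same atoms and bonds and differ only in configuration as drawn: 1 of 1 stereo elements differ; a stereocentre at a saturated ring carbon is drawn R in compound 3 and S in compound 4.

Among the compounds with values here, three measured steps bear on this only loosely: a step that the two limits leave unreadable from compound 1 to compound 2, a step that the two limits leave unreadable from compound 1 to compound 3 and a step that the two limits leave unreadable from compound 2 to compound 3. None of them has a readable size, and none is a change of configuration alone. The expectation therefore rests on compound 3, whose limit is > 90%, and on the absence of any change in atoms or bonds.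

No shift beyond the usual scatter is expected, and the expected change is a step that the limit leaves unreadable from compound 3 to compound 4. The estimate for compound 4 is 94%, with an expected range from 84% to 100%.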

Compound 4, percent of the compound remaining in the Homo sapiens assay: > 90%
Compound 4: no number, only a limit; the forecaster's own chance of this, stated with the estimate: 75%; the middle value lies beyond the limit too.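

In the Homo sapiens assay compound 4 gives > 90%, which is a limit of the assay and not a number. Within the data shown here, no step from compound 1, compound 2 or compound 3 to compound 4 can be read: the limit of > 90% in the Homo sapiens assay, at which 4 of the 4 values shown sit. The compounds shown leave open whether compound 3 and compound 4 differ at all in how much remains. In a physicochemical assay for solubility, read by HPLC, using the shake flask method, in phosphate buffer, with a stated time of 2 h, at pH 6.5 (on this read-out higher numbers stand for higher solubility and lower numbers for lower solubility), compound 3 gives 90000 nM and compound 4 gives 68000 nM. In the physicochemical assay the reading is a 1.3-fold lower number from compound 3 to compound 4 (0.12 log units; within the scatter).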